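Swapping a chloro group for a piperidine on compound 3

This account rests on a few compounds, and the source may have more. Where it says the series, first, only, none or still open, it means among the compounds named here.

The three measured compounds share a pyrazoline core carrying an acyl group, and all were tested in a functional assay on HepG2 cells (Homo sapiens) for cytotoxicity, read by MTT assay, with a stated time of 48 h; on this read-out higher numbers stand for weaker inhibition and lower numbers for stronger inhibition. Compound 1, `CC1=NN(C(=O)CN2CCCCC2)C(c2ccccc2O)C1`, gives 3020 nM. Compound 2, `C=CCN(CC=C)CC(=O)N1N=C(C)CC1c1cc(Br)ccc1O`, gives 7870 nM. Compound 3, `O=C(CCl)N1N=C(c2cc3ccccc3oc2=O)CC1c1ccccc1`, gives 2980 nM. That is the lowest of the three numbers, though the gap to compound 1 is within the scatter, so the two cannot be ordered; only compound 2 stands clearly beyond it.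

Compound 4, `CCN(CC)C1CCN(CC(=O)N2N=C(c3cc4ccccc4oc3=O)CC2c2ccccc2)CC1`, has not yet been measured. It differs from compound 3 in one place: 4-(diethylamino)piperidin-1-yl in place of chloro on a saturated chain carbon bound to a carbonyl carbon. Within the data shown here, no measured pair here shows a change of this kind, so nothing in the present numbers says how large a step to expect. A modest move toward a higher number in this assay seems a fair guess, but a step within the scatter is also possible. The estimated step of a 2.7-fold higher number from compound 3 to compound 4 (0.43 log units; beyond the scatter) reflects that expectation. Compound 4 is therefore expected to give about 8000 nM, within a range from 2500 nM to 25000 nM.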

Compound 4, half-maximal inhibitory concentration: 19300 nM
Compound 4: the middle estimate sits 2.4-fold (0.38 log units) below what was measured; low and high end bracket the measured number.
By their numbers in this assay, from the lowest: compounds 3 and 1 (each within the scatter of the next); then compound 2; then compound 4.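

In this assay, placing 4-(diethylamino)piperidin-1-yl instead of chloro on the saturated chain carbon bound to a carbonyl carbon gives a 6.5-fold higher number from compound 3 to compound 4 (0.81 log units; beyond the scatter). This is the only pair shown that differs in one place, so it offers the first direct sign that this position responds to a change: the 1 heavy atom of chloro gives way to 11 heavy atoms, and inhibition is clearly weaker. No supporting measurement available here explains the size of this step.

A single pair cannot separate the loss of chloro from the arrival of the new group, nor show which part of that group matters. It also leaves open how a smaller amine at this place, such as morpholine or dimethylamine, would compare with compound 3 and compound 4.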